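Positional isomers of the dichlorophenyl amide in a pyrazole series

This account rests on a few compounds, and the source may have more. Where it says the series, first, only, none or still open, it means among the compounds named here.

Measured compounds:
compound 1, `COc1cc(-c2nn(-c3ccc(NC(=O)c4cc(Cl)cc(Cl)c4)cc3)cc2-c2ccncc2)ccc1Cl`, > 100000 nM in a functional assay on MDA-MB-435 cells (Homo sapiens) for antiproliferative activity, read by sulforhodamine B assay, with a stated time of 48 h; a higher number here means a weaker inhibitor, a lower number a stronger inhibitor
compound 2, `O=C(Nc1ccc(-n2cc(-c3ccncc3)c(-c3ccc(Cl)c(O)c3)n2)cc1)Nc1ccc(Cl)c(C(F)(F)F)c1`, 1320 nM
compound 3, `O=C(Nc1ccc(-n2cc(-c3ccncc3)c(-c3ccc(Cl)c(O)c3)n2)cc1)c1ccc(Cl)c(Cl)c1`, 2730 nM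

Compound 1 gives only a limit in this assay, > 100000 nM, and carries no number (the limit of > 100000 nM in this assay, at which 1 of the 3 values shown sits). Of the two numbers that exist, compound 3 has the higher one; its nearest neighbour is compound 2, and the step of a 2.1-fold higher number from compound 2 to compound 3 (0.32 log units; beyond the scatter) is a modest one that lies beyond the scatter.

Compound 4, `O=C(Nc1ccc(-n2cc(-c3ccncc3)c(-c3ccc(Cl)c(O)c3)n2)cc1)c1cc(Cl)cc(Cl)c1`, has not yet been measured. It differs from compound 3 only in the amide aryl group: 3,5-dichlorophenyl in place of 3,4-dichlorophenyl on a carbonyl carbon. The two share every atom and differ only in where the second chlorine sits on that ring.

Among the compounds with values here, none of the measured steps bears directly on this change. The step from compound 2 to compound 3 exchanges a urea for an amide and says nothing about moving a chlorine within the dichlorophenyl ring. Compound 1 and compound 3 differ in two places at once, so their values alone show that one pairing reaches the limit and the other gives a number, without isolating the ring substitution.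

Within the data shown here, with no measured step to lean on, compound 4 is expected to sit close to compound 3, with a 1.0-fold lower number from compound 3 to compound 4 (0.00 log units; within the scatter) estimated as a step within the scatter, and its value is estimated at 2700 nM, between 800 nM and 9000 nM.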

Compound 4, half-maximal inhibitory concentration: 3780 nM
Compound 4: the middle estimate sits 1.4-fold (0.15 log units) below what was measured; measured number inside the range.
By their numbers in this assay, from the lowest: compound 2; then compounds 3 and 4 (each within the scatter of the next). At a limit, above all of these: compound 1.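

In this assay, moving the second chlorine so that 3,5-dichlorophenyl replaces 3,4-dichlorophenyl on the carbonyl carbon gives a 1.4-fold higher number from compound 3 to compound 4 (0.14 log units; within the scatter), so this change does not separate the two amides, while the urea compound 2 stays apart from both, with a 2.9-fold higher number from compound 2 to compound 4 (0.46 log units; beyond the scatter) matching what compound 3 had already shown. Compound 1 gives only a limit, not a number: the limit of > 100000 nM in this assay, at which 1 of the 4 values shown sits. Within the data shown here, compound 4 provides the first comparison with compound 1 that differs in one place, and hydrogen in place of methyl on an oxygen on an aromatic ring gives an at least 26-fold lower number from compound 1 to compound 4 (1.42 log units; beyond the scatter), which ties the large gap to that single change in the 3,5-dichlorophenyl amides.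

The compounds shown leave open whether the same change on that oxygen would matter as much with the 3,4-dichlorophenyl amide or with the urea of compound 2. They also leave open how the amide ring would respond to a group other than chlorine, such as an amine or a carboxylic acid.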